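Ethyl ester step from acid compound 2

This account rests on a few compounds, and the source may have more. Where it says the series, first, only, none or still open, it means among the compounds named here.

Compound 1 `CCOC(=O)/C=C/c1ccc(OC)c(OC(=O)c2nc(C)c(C)nc2C)c1`: 26.4%
Compound 2 `Cc1nc(C)c(C(=O)Oc2cccc(/C=C/C(=O)O)c2)nc1C`: 61.6%

In a functional assay on EA.hy 926 cells (Homo sapiens) for cytotoxicity, read by MTT assay, with stated times of 24 h and 12 h, tested at 12.5 uM (a higher number here means a stronger effect of the compound at the concentration tested, a lower number a weaker effect), compound 2 gives 61.6%, the highest of the two numbers shown, while compound 1 gives 26.4%, a gap beyond the usual scatter. Compound 3 `CCOC(=O)/C=C/c1cccc(OC(=O)c2nc(C)c(C)nc2C)c1` has not been measured. It differs from compound 2 by ethyl in place of hydrogen on an oxygen next to a carbonyl group. For the measured compounds named here, no measured pair separates this change alone, and compound 1 differs from compound 2 in more than one place, so only its two values can be set side by side. A downward step is expected, a number 21.6 percentage points lower from compound 2 to compound 3 (beyond the scatter), of a size beyond the scatter but not certain. Compound 3 is expected to give 40%, within 15% to 65%.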

Compound 3, a percentage reported as activity, at one concentration (the size of the read-out at that concentration, not a potency): 27.9%
Beside the measured number, compound 3's estimate is 12.1 percentage points above it; low and high end bracket the measured number.
By their numbers in this assay, from the lowest: compounds 1 and 3 (each within the scatter of the next); then compound 2.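

In this assay the step of a number 33.7 percentage points lower from compound 2 to compound 3 (beyond the scatter) comes from a single change, ethyl in place of hydrogen on an oxygen next to a carbonyl group, so this change alone carries a large step, which the earlier pair could not isolate. The step of a number 1.5 percentage points higher from compound 1 to compound 3 (within the scatter) comes from hydrogen in place of methoxy on an aromatic carbon, so with the ethoxycarbonyl group present, that methoxy makes no difference beyond the scatter. Nothing at hand gives a reason for either step. The compounds shown leave open whether a primary amide or a longer ester chain, such as propyl, would read like compound 2 or compound 3.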